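Nitro in place of methoxy: projecting compound 4

The source may report more compounds than this note shows. Statements on the series, on what has been measured and on what is new or still open speak of the compounds shown alone.

Measured compounds:
- Compound 1 `CCCCCCCCCCC(C)(C)NC(=O)c1c(OC)cc(OC)cc1OC` gives > 10000 nM in an assay on microsomes from liver for inhibition of sterol O-acyltransferase 1 (Rattus norvegicus); on this read-out higher numbers stand for weaker inhibition and lower numbers for stronger inhibition; this is a limit of the assay, not a number.
- Compound 2 `CCCCCCCCCCCCn1nnc(C(NC(=O)c2ccc(OC)cc2)c2ccccc2)n1` gives 600 nM in this assay.
- Compound 3 `CCCCCCCCCCCCn1nnc(C(NC(=O)c2ccccc2[N+](=O)[O-])c2ccccc2)n1` gives 240 nM in this assay.

Compound 2 stands at the highest of the two numbers read in this assay; its nearest neighbour is compound 3, reached by a 2.5-fold lower number from compound 2 to compound 3 (0.40 log units; beyond the scatter), a modest step beyond the scatter, made by putting 2-nitrophenyl in place of 4-methoxyphenyl on the carbonyl carbon. Compound 1 sits only at the limit of > 10000 nM in this assay, at which 1 of the 3 values shown sits, and offers no number to compare.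

Compound 4 `CCCCCCCCCCCCn1nnc(C(NC(=O)c2ccc([N+](=O)[O-])cc2)c2ccccc2)n1`, not yet measured, differs from compound 2 by nitro in place of methoxy on an aromatic carbon. Among the measured compounds shown here, the single measured step that bears on it is the one from compound 2 to compound 3: the same leaving group, the same entering group, set on the ring in a different position. That step lowered the number modestly. A step of similar direction and size is therefore expected in this assay for compound 4, though whether the position of the nitro group matters cannot be read from two compounds.

Compound 4 is estimated at 300 nM, between 120 nM and 800 nM, which would mean an expected 2.0-fold lower number from compound 2 to compound 4 (0.30 log units; within the scatter).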

Compound 4, half-maximal inhibitory concentration: 540 nM
Compound 4: the middle estimate sits 1.8-fold (0.26 log units) below what was measured; the measured number falls inside the stated range.
By their numbers in this assay, from the lowest: compound 3; then compounds 4 and 2 (each within the scatter of the next). At a limit, above all of these: compound 1.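

In this assay, nitro in place of methoxy on the aromatic carbon para to a large group gives a 1.1-fold lower number from compound 2 to compound 4 (0.05 log units; within the scatter), so at this position the exchange of groups does not separate the two compounds. The nitro group alone therefore does not go with the lower number of compound 3: 4-nitrophenyl in place of 2-nitrophenyl on the carbonyl carbon gives a 2.3-fold higher number from compound 3 to compound 4 (0.35 log units; beyond the scatter), a modest step beyond the scatter that shows the placement of the nitro group matters among these compounds. No measurement shown accounts for this difference between the two placements.

Going by these compounds, whether the lower number of compound 3 is tied to nitro itself remains open, since an amine or a nitrile in the same place on the ring would be needed to tell that group from its placement. Also open, on these data alone, is how far this placement effect carries over to other parts of the shared core, for example with a shorter chain in place of the long chain common to compound 2, compound 3 and compound 4.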